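The compounds below may be only part of what the source reports. "The series", "measured", "known", "first", "only" and "open" are said of these compounds alone.

Compound 1 `C=CC(=O)NCCCc1ccc2ncn(-c3ccnc(N)n3)c2c1` — 501000 nM
Compound 2 `CC(=O)NCCCc1ccc2ncn(-c3ccnc(N)n3)c2c1` — limit only, > 100000 nM
Compound 3 `C=Cc1ccnc(C#Cc2ccc3ncn(-c4ccnc(N)n4)c3c2)c1` — 1580 nM

In an assay on Sf9 cells for inhibition of mitogen-activated protein kinase kinase kinase 14 variant S549D (Homo sapiens), with a stated time of 30 min, in the presence of a further agent that is not named here (a higher number here means a weaker inhibitor, a lower number a stronger inhibitor), compound 1 gives 501000 nM. Compound 2 reaches only the limit of the assay, > 100000 nM. Compound 3 gives 1580 nM, the lowest of the two numbers shown, with compound 1 sitting far higher, well beyond the scatter. The step that the limit leaves unreadable from compound 1 to compound 2, methyl in place of vinyl on a carbonyl carbon, cannot be sized because of the limit of > 100000 nM in this assay, at which 1 of the 3 values shown sits.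

Compound 4 `C#Cc1cnc(C#Cc2ccc3ncn(-c4ccnc(N)n4)c3c2)nc1` differs from compound 3 by a group of 8 heavy atoms (6 carbon, 2 nitrogen; one six-membered aromatic ring with 2 hetero atoms) in place of a group of 8 heavy atoms (7 carbon, 1 nitrogen; one six-membered aromatic ring with 1 hetero atom), on a triple-bonded carbon. Among the measured compounds shown here, no measured step touches this part of the structure, so the expectation rests on compound 3 alone, and nothing points to a move beyond the scatter. Compound 4 is expected to give about 1500 nM, between 400 nM and 6000 nM. The expected step of a 1.1-fold lower number from compound 3 to compound 4 (0.02 log units; within the scatter) lies within the scatter.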

Compound 4, half-maximal inhibitory concentration: 25100 nM
The estimate for compound 4 lay 17-fold (1.22 log units) below the measured number; the whole stated range lies below it.
By their numbers in this assay, from the lowest: compound 3; then compound 4; then compound 1.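

In this assay, the group on the triple-bonded carbon proves to matter: the change there gives a 16-fold higher number from compound 3 to compound 4 (1.20 log units; beyond the scatter). Among the compounds shown here, this is the first readable step at this place, and the earlier compounds showed no change here. The swap alters both the six-membered aromatic ring with its hetero atoms and the bond outside it, so the step cannot be assigned to either alone, and nothing measured here accounts for it. The compounds shown leave open how an amine or a simple methyl group on the triple-bonded carbon would compare.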